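The compounds below may be only part of what the source reports. "The series", "measured", "known", "first", "only" and "open" are said of these compounds alone.

In a functional assay on MCF7 cells (Homo sapiens) for inhibition, read by sulforhodamine B assay (a higher number here means a weaker inhibitor, a lower number a stronger inhibitor), compound 1 `O=C1C=C(NCc2ccccc2)C(=O)c2c1nc1n2[C@H]2OC[C@@H](O)[C@H]2OC1` reaches only a limit, > 8000 nM. On these data alone, compound 2 `O=C1C=C(NC2CCCC2)C(=O)c2c1nc1n2[C@H]2OC[C@@H](O)[C@H]2OC1` also reaches only a limit, > 16000 nM, so its true potency remains unknown. For the measured compounds named here, the one measured step bearing on the next change is a step that the two limits leave unreadable from compound 1 to compound 2. It gives no size or direction to carry forward. Compound 3 `O=C1C=C(Nc2ccc(Br)cc2)C(=O)c2c1nc1n2[C@H]2OC[C@@H](O)[C@H]2OC1` follows from compound 2 through (4-bromophenyl in place of cyclopentyl on an amine nitrogen), with 4-bromophenyl in place of cyclopentyl on an amine nitrogen. With so little to go on, only a weak result near these limits is expected, with no confident direction. The expected step is an at least 1.3-fold lower number from compound 2 to compound 3 (0.12 log units; that floor lies within the scatter). Compound 3 is estimated at 12000 nM, with an expected range from 3000 nM to 32000 nM.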

Compound 3, half-maximal inhibitory concentration: 2580 nM
Beside the measured number, compound 3's estimate is 4.7-fold (0.67 log units) above it, outside the stated range (below it).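

With 4-bromophenyl on the amine nitrogen, the series gives its first readable number, which neither earlier group reached. In this assay, the change gives an at least 6.2-fold lower number from compound 2 to compound 3 (0.79 log units; beyond the scatter), and replacing benzyl gives an at least 3.1-fold lower number from compound 1 to compound 3 (0.49 log units; beyond the scatter). The first step is only a floor, because its starting value is a limit: the limit of > 16000 nM in this assay, at which 1 of the 3 values shown sits.

Whether the ring or its bromine accounts for this gain stays open, and a plain phenyl or a 4-chlorophenyl on the same nitrogen would help separate the two. On these data alone, the true size of the gain also stays open.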